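Methyl scan on the benzofuran-type core: compound 4

A few compounds are considered here, and "the series" means these few. Any claim that something is new, unique, unknown or untested is made for them only; others in the source may bear on it.

Measured compounds:
compound 1, `O=C(NCCO)c1cccc(-c2cccc3oc(Cc4cccc(C(F)(F)F)c4)cc23)c1`, 28.2 nM
compound 2, `O=C(NCCO)c1cccc(-c2cccc3cc(Cc4cccc(C(F)(F)F)c4)oc23)c1`, 34.7 nM
compound 3, `O=C(NCCO)c1cccc(-c2cccc3sc(Cc4cccc(C(F)(F)F)c4)cc23)c1`, 38 nM

All three measured compounds were run in a functional assay on CHO cells for agonist activity at G-protein coupled receptor 52 (Homo sapiens), read by AlphaScreen and cAMP accumulation, with a stated time of 30 min (a lower number here means that less compound is needed, a higher number that more compound is needed for the effect), and give numbers close together. Compound 1 gives 28.2 nM, the lowest of the three numbers, but the gap to compound 2 and to compound 3 lies within the scatter of this assay in both cases, so no order among the three can be claimed. The shared pattern is a hydroxyethyl amide on a phenyl ring attached to a fused bicyclic core carrying a 3-(trifluoromethyl)benzyl group; the three differ only in the arrangement and heteroatom of the five-membered ring.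

The unmeasured compound 4, `Cc1c(Cc2cccc(C(F)(F)F)c2)oc2cccc(-c3cccc(C(=O)NCCO)c3)c12`, differs from compound 1 in one place: methyl in place of hydrogen on an aromatic carbon. Going by the values given here, no pair of measured compounds is separated by a single change of this kind, so there is no direct precedent for its size. The three measured numbers vary little despite changes in the core itself, which suggests tolerance to small edits here. The expectation is therefore a step from compound 1 to compound 4 of about a 1.1-fold lower number from compound 1 to compound 4 (0.05 log units; within the scatter), in no clear direction and not beyond the scatter. Compound 4 is estimated at 25 nM in this assay, in a range from 9 nM to 70 nM.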

Compound 4, half-maximal effective concentration: > 10000 nM
Compound 4: no number, only a limit; the forecaster's own chance of this, stated with the estimate: 3%; middle value at least 400-fold (2.60 log units) away from the limit.
By their numbers in this assay, from the lowest: compounds 1, 2 and 3 (each within the scatter of the next). At a limit, above all of these: compound 4.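

In this assay compound 4 gives > 10000 nM, which is a limit of the assay and not a number. Methyl in place of hydrogen on this aromatic carbon of the five-membered ring, next to the ring atom that bears a 3-(trifluoromethyl)benzyl group and two ring bonds from the ring oxygen, gives an at least 350-fold higher number from compound 1 to compound 4 (2.54 log units; beyond the scatter), so one small addition at this position outweighs anything visible among the close numbers of compounds 1, 2 and 3. Those close numbers therefore do not carry over to substitution on this carbon, and the size of the step is read against a limit of the assay: the limit of > 10000 nM in this assay, at which 1 of the 4 values shown sits.

The compounds shown do not tell whether the effect belongs to methyl in particular or to any group other than hydrogen on this carbon; fluorine, chlorine, a methoxy group or an ethyl group at the same place would separate these cases. They also leave open whether the same methyl on the core of compound 3 gives a step of similar size, and no cause for the step can be read from these data.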